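Trimming the Amine on a Shared Core

The source may report more compounds than this note shows. Statements on the series, on what has been measured and on what is new or still open speak of the compounds shown alone.

Measured compounds:
compound 1, `O=C1C(=O)N(CN2CCCCC2)c2cccc(Cl)c21` — 82800 nM
compound 2, `CCN(CC)CN1C(=O)C(=O)c2c(Cl)cccc21` — 28300 nM

Of the compounds shown here, two have been tested in a functional assay on MDA-MB-468 cells (Homo sapiens) for cytotoxicity, read by sulforhodamine B assay, with a stated time of 48 h; a lower number here means a stronger inhibitor of growth, a higher number a weaker inhibitor of growth. In this assay compound 1 gives 82800 nM, and compound 2 gives 28300 nM. Among the measured compounds shown here, compound 2 therefore holds the lower of the two numbers, its only neighbour being compound 1, separated by the step of a 2.9-fold lower number from compound 1 to compound 2 (0.47 log units; beyond the scatter), which lies beyond the scatter.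

The next compound, compound 3, is `CN(C)CN1C(=O)C(=O)c2c(Cl)cccc21`. It differs from compound 2 in one place: dimethylamino in place of diethylamino on a saturated chain carbon bound to an amide-type nitrogen in a ring. For the measured compounds named here, the one measured step that bears on this change is a 2.9-fold lower number from compound 1 to compound 2 (0.47 log units; beyond the scatter), a swap of the amine at the same place, which reduced the number by a modest amount. That single step does not show whether a further reduction in the size of the amine continues in the same direction, so the expected step of a 1.3-fold lower number from compound 2 to compound 3 (0.11 log units; within the scatter) is small, most likely within the scatter, with a slight lean toward a lower number. Compound 3 is thus estimated at 22000 nM, with a range from 7000 nM to 70000 nM.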

Compound 3, concentration for 50% growth inhibition: 107000 nM
Compound 3: middle estimate off by 4.9-fold (0.69 log units), on the low side; measured number above the stated range.
By their numbers in this assay, from the lowest: compound 2; then compounds 1 and 3 (each within the scatter of the next).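

Going from diethylamino to dimethylamino on this saturated chain carbon, this assay records a 3.8-fold higher number from compound 2 to compound 3 (0.58 log units; beyond the scatter) and so the fall in the number seen on going from piperidin-1-yl to diethylamino does not carry on as the amine is trimmed further. The comparison of the two outer amines gives a 1.3-fold higher number from compound 1 to compound 3 (0.11 log units; within the scatter) and places dimethylamino and piperidin-1-yl level with each other, which leaves compound 2, with its diethylamino group, as the strongest inhibitor of growth of the three and shows that among these amines the response at this position does not run in one direction with the number of carbons. Nothing available here offers a measured explanation for this turn in the series.

Going by these compounds, with only three amines on the shared core, it remains open whether the advantage belongs to diethylamino alone or extends to close relatives such as dipropylamino, N-ethyl-N-methylamino or pyrrolidin-1-yl. Also open, on these data alone, is whether the same order would hold with morpholin-4-yl as the amine or with a longer chain joining the amine to the ring nitrogen.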